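Halogen swap on the amide end of a cytotoxicity series

A few compounds are considered here, and "the series" means these few. Any claim that something is new, unique, unknown or untested is made for them only; others in the source may bear on it.

Four compounds share one long chain and differ only at its two ends. Compound 1 `O=C(CN1CCN(C(=O)c2cccc(F)c2)CC1)N1CCN(CCCc2c[nH]c3ccc(F)cc23)CC1` carries a 3-fluorophenyl on the carbonyl carbon; in an ADME assay on HEK293 cells (Homo sapiens) for cytotoxicity, read by MTT assay, with a stated time of 72 h (on this read-out lower numbers stand for stronger inhibition and higher numbers for weaker inhibition), compound 1 gives 83000 nM. Compound 2 `O=C(CN1CCN(C(=O)c2ccccc2Br)CC1)N1CCN(CCCc2c[nH]c3ccc(F)cc23)CC1` differs by 2-bromophenyl in place of 3-fluorophenyl on a carbonyl carbon and in this assay compound 2 gives 77100 nM, so this change produced a 1.1-fold lower number from compound 1 to compound 2 (0.03 log units; within the scatter). Compound 3 `COc1ccc2[nH]cc(CCCN3CCN(C(=O)CN4CCN(C(=O)c5cccc(F)c5)CC4)CC3)c2c1` has a different core, the difference being (methoxy in place of fluoro on an aromatic carbon). In this assay compound 3 gives only a limit of the assay, > 200000 nM, not a number. From this the step is an at least 2.4-fold higher number from compound 1 to compound 3 (0.38 log units; beyond the scatter). Compound 4 `COc1ccc2[nH]cc(CCCN3CCN(C(=O)CN4CCN(C(=O)c5ccccc5Br)CC4)CC3)c2c1` is not yet measured; it differs from compound 3 by 2-bromophenyl in place of 3-fluorophenyl on a carbonyl carbon, the same change as from compound 1 to compound 2, made at a place described in the very same words. The step to compound 4 is expected to be a number no higher from compound 3 to compound 4 (the limit leaves the size open) because the earlier one was a 1.1-fold lower number from compound 1 to compound 2 (0.03 log units; within the scatter). Compound 4 is therefore expected to give 200000 nM in this assay, between 100000 nM and 400000 nM, and may well again sit at the limit of > 200000 nM in this assay, at which 1 of the 3 values shown sits.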

Compound 4, half-maximal inhibitory concentration: 163000 nM
Compound 4: middle estimate off by 1.2-fold (0.09 log units), on the high side; measured number inside the range.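

In this assay, 2-bromophenyl in place of 3-fluorophenyl on a carbonyl carbon gives an at least 1.2-fold lower number from compound 3 to compound 4 (0.08 log units; that floor lies within the scatter), so nothing here shows the change behaving differently on the two cores, yet nothing shows it behaving alike either: the same change on two cores in this assay, a 1.1-fold lower number (0.03 log units; within the scatter) from compound 1 to compound 2 and an at least 1.2-fold lower number (0.08 log units; that floor lies within the scatter) from compound 3 to compound 4; the limit leaves it open whether they differ

The value of compound 3, > 200000 nM, is a limit of the assay and not a number.

The other change, methoxy in place of fluoro on an aromatic carbon, gives a 2.1-fold higher number from compound 2 to compound 4 (0.33 log units; beyond the scatter), and it can be set against the same step with the 3-fluorophenyl group in place: the same change on two cores in this assay, an at least 2.4-fold higher number (0.38 log units; beyond the scatter) from compound 1 to compound 3 and a 2.1-fold higher number (0.33 log units; beyond the scatter) from compound 2 to compound 4; the limit leaves it open whether they differ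

On these data alone, it remains open whether the small step from the halogen swap would hold with a nitrile or an amine in place of the fluoro or methoxy group on the core. The compounds shown also leave open what a longer chain would do to either step.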